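A Larger Aryl Group Replaces Methylsulfanyl

A few compounds are considered here, and "the series" means these few. Any claim that something is new, unique, unknown or untested is made for them only; others in the source may bear on it.

In an ADME assay on S9 fraction from liver (Rattus norvegicus) for metabolic stability, read by LC-MS, using NADPH, with a stated time of 30 min (on this read-out lower numbers stand for a less stable compound and higher numbers for a more stable compound), compound 1 `CCCCCCCCc1ccc(OCC(=O)Cn2nnc(C(=O)OC)n2)cc1` reads < 5%, which is a limit of the assay and not a number. Among the compounds with values here, compound 2 `CCCCCCCCc1ccc(OCC(=O)Cn2nnnc2SC)cc1` gives 21%, the only actual number so far. Compound 3 `CCCCCCCCc1ccc(OCC(=O)Cn2nnnc2-c2cccc(S(=O)(=O)N(C)C)c2)cc1` differs from it by 3-(dimethylsulfamoyl)phenyl in place of methylsulfanyl on an aromatic carbon, with 3-(dimethylsulfamoyl)phenyl in place of methylsulfanyl on an aromatic carbon. Resting on a number at least 16 percentage points higher from compound 1 to compound 2 (beyond the scatter) as the only measured step that bears on this place, no shift beyond the scatter is expected, the estimate being a number 5 percentage points lower from compound 2 to compound 3 (within the scatter). Compound 3 is estimated at 16%, with an expected range of 5% to 40%.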

Compound 3, percent of the compound remaining: 24%
For compound 3 the middle estimate is 8 percentage points below the measured one; low and high end bracket the measured number.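

In this assay, 3-(dimethylsulfamoyl)phenyl in place of methylsulfanyl gives a number 3 percentage points higher from compound 2 to compound 3 (within the scatter) and so shows that this aromatic carbon carries a far larger group, with a six-membered aromatic ring, without a shift beyond the scatter. Within the data shown here, this is the first step read between two actual numbers. Compound 1 stands at a limit of the assay and not at a number: the limit of < 5% in this assay, at which 1 of the 3 values shown sits.

From the compounds shown here alone, what an amine or a carboxylic acid on this aromatic carbon would read remains open. Also open, going by these compounds, is whether an unsubstituted phenyl would read like compound 3.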